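The source may hold more compounds than are shown below. What is called first, only, known or untested is meant among the compounds shown, and "the series" means these compounds.

Working notes on the series. In a functional assay on HCT-116 cells (Homo sapiens) for antiproliferative activity, with a stated time of 72 h (a higher number here means a weaker inhibitor, a lower number a stronger inhibitor), compound 3 (`Nc1ncnn2c([C@@H]3O[C@H](CO)[C@@H](O)[C@H]3O)cc(-c3ccoc3)c12`) gives the lowest number (1400 nM). Compound 1 (`Nc1ncnn2c([C@@H]3O[C@H](CO)[C@@H](O)[C@H]3O)cc(C#Cc3cccs3)c12`) gives a much higher number (65500 nM), and the gap is large (a 47-fold lower number from compound 1 to compound 3 (1.67 log units; beyond the scatter)). Compound 2 (`Cc1ccccc1-c1cc([C@@H]2O[C@H](CO)[C@@H](O)[C@H]2O)n2ncnc(N)c12`) returns only a limit (> 100000 nM).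

The next step leads to compound 4 (`Nc1ncnn2c([C@@H]3O[C@H](CO)[C@@H](O)[C@H]3O)cc(-c3ccccc3Cl)c12`), which carries 2-chlorophenyl in place of furan-3-yl on an aromatic carbon. The closest measured precedent is the step between compound 2 and compound 3 (an at least 71-fold lower number from compound 2 to compound 3 (1.85 log units; beyond the scatter)), where 2-methylphenyl gives way to furan-3-yl at the same place. Compound 4 reverses that exchange with a different 2-substituted phenyl, so a large rise in the number is expected in this assay. The step between compound 1 and compound 2 (an at least 1.5-fold higher number from compound 1 to compound 2 (0.18 log units; that floor lies within the scatter)) does not separate those two, and both lie far from compound 3. Among the compounds with values here, the evidence rests on only three compounds, and none of them carries a chlorine-bearing group.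

The expected step is large and upward (a 29-fold higher number from compound 3 to compound 4 (1.46 log units; beyond the scatter)). Compound 4 is estimated at (40000 nM), with an expected range from (8000 nM) to (100000 nM).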

Compound 4, half-maximal inhibitory concentration: > 100000 nM
Compound 4 was reported as a limit; the forecaster's own chance of this, stated with the estimate: 40%; middle value at least 2.5-fold (0.39 log units) from the limit.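

In this assay, 2-chlorophenyl at this place gives an at least 71-fold higher number from compound 3 to compound 4 (1.85 log units; beyond the scatter), so the loss seen with 2-methylphenyl also appears with a second 2-substituted phenyl, and furan-3-yl is now the only group shown with a readable value below the limit of the assay apart from 2-(thiophen-2-yl)ethynyl. The other readable step is an at least 1.5-fold higher number from compound 1 to compound 4 (0.18 log units; that floor lies within the scatter), so the data do not separate 2-chlorophenyl from 2-(thiophen-2-yl)ethynyl. Compound 2 and compound 4 are both reported as limits, and the step between them, chloro in place of methyl, cannot be read: the limit of > 100000 nM in this assay, at which 2 of the 4 values shown sit.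

The compounds shown leave open whether the lower number of compound 3 follows the five-membered aromatic ring, its oxygen or the absence of a 2-substituent, as furan-3-yl is the only group of its kind here. Phenyl without a substituent, thiophen-3-yl or an amine on the same aromatic carbon would help tell these readings apart, and the reach of the pattern beyond these four compounds remains unknown.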